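The source may report more compounds than this note shows. Statements on the series, on what has been measured and on what is new or still open speak of the compounds shown alone.

Measured compounds and their values in a functional assay on CCRF-CEM cells (Homo sapiens) for antiproliferative activity, read by MTT assay, with a stated time of 48 h, tested at 12.5 uM; a higher number here means a weaker effect of the compound at the concentration tested, a lower number a stronger effect:

compound 1, `OC(CCn1nc2c(Br)c(Br)c(Br)c(Br)c2n1)c1cccc(Cl)c1`: 70%
compound 2, `OC(CCn1nc2c(Br)c(Br)c(Br)c(Br)c2n1)c1ccccc1`: 89%
compound 3, `OC(CCn1nc2c(Br)c(Br)c(Br)c(Br)c2n1)c1ccc(Br)cc1`: 89%

Compound 3 stands level with compound 2 at the digits shown; together they give the two highest numbers of the three, which in this assay means the weakest effect. Within the data shown here, the step of no change at the digits printed from compound 2 to compound 3 (within the scatter) lies within the scatter, while the step of a number 19 percentage points higher from compound 1 to compound 3 (beyond the scatter) is a modest one beyond it, so compound 1 is the only measured compound with a clearly stronger effect.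

Compound 4, `CC(O)CCn1nc2c(Br)c(Br)c(Br)c(Br)c2n1`, differs from compound 3 by methyl in place of 4-bromophenyl on a saturated chain carbon bound to an oxygen on a saturated carbon and a saturated chain carbon. Among the measured compounds shown here, no measured step removes the aromatic ring from this position; the two steps that touch this part of the molecule, no change at the digits printed from compound 2 to compound 3 (within the scatter) and a number 19 percentage points higher from compound 1 to compound 3 (beyond the scatter), only exchange substituents on it and gave at most a modest shift. With compound 3 already among the highest numbers, the expectation for compound 4 is a step of a number 4 percentage points higher from compound 3 to compound 4 (within the scatter), which is within the scatter. Compound 4 is thus estimated at 93%, with a range from 78% to 105%.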

Compound 4, a percentage reported as activity, at one concentration (the size of the read-out at that concentration, not a potency): 94%
Estimate against measurement, compound 4: 1 percentage points below; the range from low to high includes it.
By their numbers in this assay, from the lowest: compound 1; then compounds 2, 3 and 4 (each within the scatter of the next).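

In this assay, the whole aromatic ring at this position can give way to a single methyl with only a number 5 percentage points higher from compound 3 to compound 4 (within the scatter) and a number 5 percentage points higher from compound 2 to compound 4 (within the scatter), so having a phenyl or 4-bromophenyl ring here gives no measurable gain over methyl. Only the 3-chlorophenyl group stands apart, with a number 24 percentage points higher from compound 1 to compound 4 (beyond the scatter) on the same change, so the stronger effect of compound 1 goes with that particular ring and not with any aromatic ring at this position. Nothing available explains why this ring differs from the other two.

On these data alone, it remains open whether the difference lies in chloro itself or in where it sits on the ring, which 4-chlorophenyl and 3-bromophenyl could separate. As far as these compounds go, how an amine, a carboxylic acid or a longer chain would read in place of methyl also remains open.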